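The source may hold more compounds than are shown below. What is called first, only, known or untested is meant among the compounds shown, and "the series" means these compounds.

Two compounds share a core built around an amide of a hydroxylated pyrrolidine, attached through a benzyl linker to a five-membered aromatic ring that carries a long side group. Compound 1 `CCCCCCCc1cc(-c2ccc(CNC(=O)[C@H]3NCC[C@@H]3O)cc2)n[nH]1` carries a heptyl chain; in an assay on isolated protein for inhibition of sphingosine kinase 1 (Homo sapiens) (a higher number here means a weaker inhibitor, a lower number a stronger inhibitor), compound 1 gives 1100 nM. Compound 2 `CCCCCCc1nc(-c2ccc(CNC(=O)[C@H]3NCC[C@@H]3O)cc2)no1` carries a hexyl chain on a different five-membered ring, and in this assay compound 2 gives 49 nM. Of these two numbers, compound 2 has the lower one, and the gap to compound 1 lies beyond the usual scatter.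

Compound 3 `CC1(c2nc(-c3ccc(CNC(=O)[C@H]4NCC[C@@H]4O)cc3)no2)CCCCC1` keeps the whole frame of compound 2 and changes only the side group: 1-methylcyclohexyl in place of hexyl on an aromatic carbon. Among the compounds with values here, no measured pair shows what such a change does here. A step of a 1.6-fold higher number from compound 2 to compound 3 (0.21 log units; within the scatter) toward a somewhat higher number is expected, but it is as likely to fall within the scatter as beyond it. Compound 3 is therefore expected to give about 80 nM, within a range of 25 nM to 300 nM.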

Compound 3, half-maximal inhibitory concentration: 210 nM
Compound 3: middle estimate off by 2.6-fold (0.42 log units), on the low side; the range from low to high includes it.
By their numbers in this assay, from the lowest: compound 2; then compound 3; then compound 1.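

In this assay, placing 1-methylcyclohexyl instead of hexyl on this aromatic carbon gives a 4.3-fold higher number from compound 2 to compound 3 (0.63 log units; beyond the scatter) and so costs potency beyond the usual scatter. Within the data shown here, this is the first sign that this position on the shared core is sensitive to which side group it carries. Both groups are made of carbon only, with no hydrogen-bond donors or acceptors and no net charge, so the clearest difference in their make-up is an open chain against a ring, and no measurement here explains the step.

On these data alone, it remains open whether the ring itself or the added methyl accounts for the weaker inhibition. A plain cyclohexyl group would help separate the two, while an octyl chain would show whether a longer open chain is tolerated at this position.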